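The source may report more compounds than this note shows. Statements on the series, on what has been measured and on what is new or still open speak of the compounds shown alone.

In an ADME assay on HEK293 cells (Homo sapiens) for cytotoxicity, with a stated time of 72 h (a lower number here means that less compound is needed, a higher number that more compound is needed for the effect), compound 3, `O=C(Nc1ccc(-c2ccccc2)cc1)c1cc([N+](=O)[O-])ccc1Cl`, gives only a limit, > 27000 nM, and not a number. The two compounds measured beside it reach only limits as well. Compound 1, `O=C(Nc1ccc(O)c(-c2nc3ccccc3s2)c1)c1cc([N+](=O)[O-])ccc1Cl`, gives the limit > 25000 nM in this assay. Compound 2, `O=C(Nc1nc2ccc(F)cc2s1)c1cc([N+](=O)[O-])ccc1Cl`, gives the limit > 27000 nM in this assay. Thus none of the three yields a number: one value sits at the limit of > 25000 nM in this assay, at which 1 of the 3 values shown sits, and two sit at the limit of > 27000 nM in this assay, at which 2 of the 3 values shown sit. For the measured compounds named here, compound 3 therefore stands exactly where every other value stands, at the edge of what this assay reports, and no step between measured compounds can be drawn from these data.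

Compound 4, `O=C(Nc1ccc(-c2nc3ccccc3s2)cc1)c1cc([N+](=O)[O-])ccc1Cl`, has not yet been measured in this assay. It differs from compound 3 by 1,3-benzothiazol-2-yl in place of phenyl on an aromatic carbon. The change is expected to leave the outcome unchanged, since compound 1 already carries the 1,3-benzothiazol-2-yl group and still gives only the limit > 25000 nM in this assay. The expected step is a number no higher from compound 3 to compound 4 (the limit leaves the size open), that is, none beyond the scatter, in neither direction. Compound 4 is accordingly estimated at 27000 nM, with a range from 10000 nM to 60000 nM, and most probably this assay will again report only a limit for it.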

Compound 4, half-maximal effective concentration: > 27000 nM
Compound 4: no number, only a limit (the forecaster's own chance of this, stated with the estimate: 85%); the middle value sits exactly at the limit.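

In this assay, for the compounds shown here, compound 4 gives only a limit, as compound 3 does, so no step between compound 3 and compound 4 can be read. The compounds shown leave open what concentration any of them needs for the half-maximal effect, and whether 1,3-benzothiazol-2-yl in place of phenyl changes that concentration at all.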